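A few compounds are considered here, and "the series" means these few. Any claim that something is new, unique, unknown or untested is made for them only; others in the source may bear on it.

Working notes on the series.

Compound 1 `COc1cc(N)c(Cl)cc1NC(=O)C1CCN(Cc2ccccc2Cl)CC1` is measured in a functional assay on the whole organism for antagonist activity, with Mus musculus as the target; on this read-out higher numbers stand for an effect only at larger amounts of compound and lower numbers for an effect already at smaller amounts. In this assay compound 1 gives > 4 mg/kg, which is a limit of the assay and not a number. Compound 2 `CCCCCN1CCC(C(=O)Nc2cc(Cl)c(N)cc2OC)CC1` gives > 10 mg/kg in this assay, again a limit rather than a number. Compound 3 `COc1cc(N)c(Cl)cc1NC(=O)C1CCN(Cc2cccc(Cl)c2)CC1`, the parent of the step followed here, gives > 4 mg/kg in this assay; this too is only a limit. Compound 3 therefore stands at the limit of > 4 mg/kg in this assay, at which 2 of the 3 values shown sit, while compound 2 sits at the limit of > 10 mg/kg in this assay, at which 1 of the 3 values shown sits, and no ordering among the three can be read.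

The measured steps confirm this: a step that the two limits leave unreadable from compound 1 to compound 2, a step that the two limits leave unreadable from compound 1 to compound 3 and a step that the two limits leave unreadable from compound 2 to compound 3 are all left unreadable by the limits on both sides.

Compound 4 `COc1ccc(CN2CCC(C(=O)Nc3cc(Cl)c(N)cc3OC)CC2)cc1` differs from compound 3 by 4-methoxyphenyl in place of 3-chlorophenyl on a saturated chain carbon bound to an amine nitrogen in a ring, a change on the saturated chain carbon bound to the amine nitrogen in the ring, the same place where the three measured steps act. Since every measured step at that place is unreadable, no size or direction can be expected for the step in this assay beyond the possibility that compound 4 also ends at a limit.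

The estimate for compound 4 in this assay is 8 mg/kg, with a range from 3 mg/kg to 30 mg/kg, which corresponds to an expected step that the limit leaves unreadable from compound 3 to compound 4.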

Compound 4, dose for half-maximal effect: 0.9 mg/kg
Estimate against measurement, compound 4: 8.9-fold (0.95 log units) above, and the stated range ends above it.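

In this assay, among the compounds shown here, 4-methoxyphenyl on a saturated chain carbon bound to an amine nitrogen in a ring gives the first readable steps at this place: against 3-chlorophenyl there is an at least 4.4-fold lower number from compound 3 to compound 4 (0.64 log units; beyond the scatter), against 2-chlorophenyl there is an at least 4.4-fold lower number from compound 1 to compound 4 (0.64 log units; beyond the scatter), and against butyl there is an at least 11-fold lower number from compound 2 to compound 4 (1.04 log units; beyond the scatter), while the steps among compound 1, compound 2 and compound 3 cannot be read. Each of these three new steps is open-ended, as compound 1 and compound 3 each stay at a limit: the limit of > 4 mg/kg in this assay, at which 2 of the 4 values shown sit. Compound 2 also stays at a limit: the limit of > 10 mg/kg in this assay, at which 1 of the 4 values shown sits.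

The compounds shown leave open whether the lower number goes with the methoxy group itself or with its place on the phenyl ring, a question that 4-chlorophenyl and 3-methoxyphenyl on the same carbon would separate. Going by these compounds, the full size of all three steps also stays open, as does the outcome with a longer chain between the amine nitrogen and the 4-methoxyphenyl ring.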